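Two cell-toxicity limits and a methoxy-to-hydroxy exchange

The source may hold more compounds than are shown below. What is called first, only, known or untested is meant among the compounds shown, and "the series" means these compounds.

Measured compounds:
- compound 1 `O=C(Nc1cccc(-n2cc(-c3ccncc3)c(-c3ccc(Cl)c(O)c3)n2)c1)Nc1cccc(C(F)(F)F)c1`: > 32500 nM
- compound 2 `COc1cc(-c2nn(-c3cccc(NC(=O)Nc4ccc(Cl)c(Cl)c4)c3)cc2-c2ccncc2)ccc1Cl`: > 50000 nM

In a functional assay on U-251 cells (Homo sapiens) for inhibition, read by sulforhodamine B assay, with a stated time of 48 h (on this read-out lower numbers stand for higher toxicity in this test and higher numbers for lower toxicity in this test), compound 1 reaches only the limit of the test, (the limit of > 32500 nM in this assay, at which 1 of the 2 values shown sits). Compound 2 likewise gives no number in this assay but only a limit, (the limit of > 50000 nM in this assay, at which 1 of the 2 values shown sits). Among the compounds with values here, compound 2 therefore stands at the upper boundary of what this assay reports, and the one further value shown, that of compound 1, is also a limit, so no step between them can be sized.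

Compound 3 `O=C(Nc1cccc(-n2cc(-c3ccncc3)c(-c3ccc(Cl)c(O)c3)n2)c1)Nc1ccc(Cl)c(Cl)c1` differs from compound 2 in one place: hydrogen in place of methyl on an oxygen on an aromatic ring, or methoxy to hydroxy on the 4-chloro-3-methoxyphenyl group. Compound 1 already carries this same hydroxy group together with a different urea end and sits at a limit.

No step beyond the scatter is expected in this assay from this exchange; the step of a number no higher from compound 2 to compound 3 (the limit leaves the size open) is estimated to stay within the usual scatter. Compound 3 is expected to give about 50000 nM, within 20000 nM to 100000 nM, most likely again as a limit.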

Compound 3, concentration lethal to 50% of the cells: > 32500 nM
Compound 3 ended at the assay's limit (the forecaster's own chance of this, stated with the estimate: 80%); the middle value is on the limit's open side.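

Compound 3 gives only a limit in this assay, as do compound 1 and compound 2, so neither the step from compound 2 to compound 3 nor the step from compound 1 to compound 3 can be read: the limit of > 32500 nM in this assay, at which 2 of the 3 values shown sit.

Left open is whether methoxy to hydroxy, or the change of urea end, alters toxicity in this assay at all.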